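Phenyl in Place of Isobutyl on a Sulfonamide Nitrogen

This account rests on a few compounds, and the source may have more. Where it says the series, first, only, none or still open, it means among the compounds named here.

Within the data shown here, compound 2 `CC[C@@H]1C(=O)N(C)c2cnc(Nc3ccc(S(=O)(=O)NCC(C)C)cc3)nc2N1C1CCCC1` holds the lowest of the two numbers measured in a functional assay on NCI-H1975 cells (Homo sapiens) for antiproliferative activity, read by CCK-8 assay, with a stated time of 72 h (on this read-out lower numbers stand for stronger inhibition of growth and higher numbers for weaker inhibition of growth), where compound 2 gives 1040 nM; its only neighbour, compound 1 `CC[C@@H]1C(=O)N(C)c2cnc(Nc3ccc(S(N)(=O)=O)cc3)nc2N1C1CCCC1`, gives 5290 nM. Compound 3 `CC[C@@H]1C(=O)N(C)c2cnc(Nc3ccc(S(=O)(=O)Nc4ccccc4)cc3)nc2N1C1CCCC1` differs from compound 2 by phenyl in place of isobutyl on a sulfonamide nitrogen. Among the measured compounds shown here, the single measured step, a 5.1-fold lower number from compound 1 to compound 2 (0.71 log units; beyond the scatter), concerns a different substitution on the same sulfonamide nitrogen and so gives only loose guidance here. A step in this assay close to the scatter is expected, a 1.0-fold lower number from compound 2 to compound 3 (0.02 log units; within the scatter), with no firm direction. Compound 3 is therefore estimated at 1000 nM, within a range of 300 nM to 3500 nM.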

Compound 3, concentration for 50% growth inhibition: 6000 nM
Compound 3: middle estimate off by 6.0-fold (0.78 log units), on the low side; the whole stated range lies below it.
By their numbers in this assay, from the lowest: compound 2; then compounds 1 and 3 (each within the scatter of the next).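

In this assay the group on the sulfonamide nitrogen matters by its identity: phenyl in place of isobutyl gives a 5.8-fold higher number from compound 2 to compound 3 (0.76 log units; beyond the scatter) and shows that the better number of compound 2 does not come with just any carbon group there. Phenyl in place of hydrogen gives a 1.1-fold higher number from compound 1 to compound 3 (0.05 log units; within the scatter) and so leaves no readable change from the bare sulfonamide. Nothing measured here explains why isobutyl and phenyl part. Open, as far as these compounds go, is whether a longer chain, a cyclohexyl ring or a benzyl group on this nitrogen would follow isobutyl or phenyl.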